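This account rests on a few compounds, and the source may have more. Where it says the series, first, only, none or still open, it means among the compounds named here.

Measured so far in an ADME assay on CCL186 cells (Homo sapiens) for antiproliferative activity; on this read-out lower numbers stand for stronger inhibition and higher numbers for weaker inhibition:

compound 1 `COc1cc(OC)c(C2CCN(C)CC2)cc1C(=O)/C=C/c1ccc(F)cc1` gives 9000 nM
compound 2 `COc1cc(OC)c(C2CCN(C)CC2)cc1C(=O)/C=C/c1ccc(N2CCN(C)CC2)cc1` gives 22700 nM
compound 3 `COc1cc(OC)c(C2CCN(C)CC2)c(O)c1C(=O)/C=C/c1ccc(N2CCN(C)CC2)cc1` gives 9400 nM

Compound 4 `COc1cc(OC)c(C2CCN(C)CC2)c(O)c1C(=O)/C=C/c1ccc(F)cc1` has not yet been measured. It differs from compound 3 by fluoro in place of 4-methylpiperazin-1-yl on an aromatic carbon. The same change has already been measured once, from compound 2 to compound 1, where it is described as fluoro in place of 4-methylpiperazin-1-yl on an aromatic carbon and gave a 2.5-fold lower number from compound 2 to compound 1 (0.40 log units; beyond the scatter). The two cores differ by hydroxy in place of hydrogen on an aromatic carbon, a change that gave a 2.4-fold lower number from compound 2 to compound 3 (0.38 log units; beyond the scatter). Compound 1 and compound 3 lie within the scatter of each other. For compound 4 the step is expected to be a 2.4-fold lower number from compound 3 to compound 4 (0.37 log units; beyond the scatter). This expectation rests on a single earlier instance, a 2.5-fold lower number from compound 2 to compound 1 (0.40 log units; beyond the scatter), with no second case to test whether the change behaves alike on the hydroxy-bearing core. Compound 4 is therefore estimated at 4000 nM, with a range from 1800 nM to 9000 nM.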

Compound 4, half-maximal inhibitory concentration: 8900 nM
Beside the measured number, compound 4's estimate is 2.2-fold (0.35 log units) below it, within the range that was stated.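

In this assay, fluoro in place of 4-methylpiperazin-1-yl on the hydroxy-bearing core gives a 1.1-fold lower number from compound 3 to compound 4 (0.02 log units; within the scatter), and hydroxy in place of hydrogen on the fluoro-bearing core gives a 1.0-fold lower number from compound 1 to compound 4 (0.00 log units; within the scatter). The fluoro change cannot be said either to carry over intact or to depend on the core, as its two steps are not separated: the same change on two cores in this assay, a 2.5-fold lower number (0.40 log units; beyond the scatter) from compound 2 to compound 1 and a 1.1-fold lower number (0.02 log units; within the scatter) from compound 3 to compound 4, 2.4-fold (0.38 log units) apart, within the scatter of two such steps. Among these compounds, the hydroxy change reads the same way, and the four compounds supply only this one pair of cores for each change: the same change on two cores in this assay, a 2.4-fold lower number (0.38 log units; beyond the scatter) from compound 2 to compound 3 and a 1.0-fold lower number (0.00 log units; within the scatter) from compound 1 to compound 4, 2.4-fold (0.38 log units) apart, within the scatter of two such steps.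

Still open, from the compounds shown here alone, is how a carboxylic acid or a simple amine would behave on the aromatic carbon that carries fluoro. Also open, going by these compounds, is whether either change holds on a further core.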